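A Second Methyl on the Amide Nitrogen

A few compounds are considered here, and "the series" means these few. Any claim that something is new, unique, unknown or untested is made for them only; others in the source may bear on it.

Compound 2 `CNC(=O)CC1CCc2cc(OC)c(OC)cc21` has been tested in a functional assay on the whole organism (strain Wistar) for inhibition, with Rattus norvegicus as the target, read by paw edema, with stated times of 60 min and 24 h, at a dose of 100 mg/kg by the oral route (on this read-out higher numbers stand for more inhibition at the one dose given (going by the name of the read-out) and lower numbers for less inhibition), where compound 2 gives 33.3%. Compound 1 `COc1cc2c(cc1OC)C(CC(N)=O)CC2` gives 26.7% in this assay, and the two numbers lie within the scatter of each other. Compound 3 `COc1cc2c(cc1OC)C(CC(=O)N(C)C)CC2` differs from compound 2 by methyl in place of hydrogen on an amide-type nitrogen. Among the measured compounds shown here, the one measured step that bears on this is a number 6.6 percentage points higher from compound 1 to compound 2 (within the scatter), the same kind of change made one stage earlier. That step lay within the scatter, so no step beyond the scatter is expected here either, and a number 1.7 percentage points higher from compound 2 to compound 3 (within the scatter) is the estimated size. Compound 3 is therefore expected to give 35%, between 20% and 50%.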

Compound 3, a percentage reported as inhibition, in the whole organism at one dose (the size of the read-out at that dose, not a potency): 23.3%
For compound 3 the middle estimate is 11.7 percentage points above the measured one; measured number inside the range.
By their numbers in this assay, from the lowest: compounds 3, 1 and 2 (each within the scatter of the next).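

Going from compound 2 to compound 3 in this assay gives a number 10 percentage points lower from compound 2 to compound 3 (within the scatter) and going from compound 1 to compound 3 gives a number 3.4 percentage points lower from compound 1 to compound 3 (within the scatter) on the same read-out. Amino, methylamino and dimethylamino on this carbonyl carbon therefore cannot be told apart here, so replacing the amide hydrogens with methyl leaves no step beyond the scatter. Nothing measured here gives a reason for this result. Still open, going by these compounds, is whether a longer chain on the amide nitrogen, such as ethyl, or a carboxylic acid in place of the amide would shift the number beyond the scatter.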